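Replacing the Sulfonyl Amine of Compound 2 with Hexyloxy

This account rests on a few compounds, and the source may have more. Where it says the series, first, only, none or still open, it means among the compounds named here.

Measured so far:
Compound 1 `CC(C)c1cccc(C(C)C)c1NC(=O)NS(=O)(=O)N1CCCC1`; in an assay on liver for inhibition of sterol O-acyltransferase 1 (Rattus norvegicus), using microsomes (on this read-out lower numbers stand for stronger inhibition and higher numbers for weaker inhibition), compound 1 gives 15000 nM.
Compound 2 `CC(C)CN(CC(C)C)S(=O)(=O)NC(=O)Nc1c(C(C)C)cccc1C(C)C`; in this assay compound 2 gives 420 nM.

Within the data shown here, compound 2 holds the lower of the two numbers, and the single measured step, a 36-fold lower number from compound 1 to compound 2 (1.55 log units; beyond the scatter), is what separates it from compound 1. Compound 3 `CCCCCCOS(=O)(=O)NC(=O)Nc1c(C(C)C)cccc1C(C)C` carries hexyloxy in place of diisobutylamino on a sulfonyl sulfur. Among the measured compounds shown here, the only step that bears on this position is a 36-fold lower number from compound 1 to compound 2 (1.55 log units; beyond the scatter), which shows that exchanging the group on the sulfonyl sulfur can shift the read-out by a large margin. For the measured compounds named here, that step swapped one amino group for another; compound 3 instead places an oxygen-linked chain there, a change for which no measured pair exists. A step toward weaker inhibition is expected, smaller than that earlier one: a 3.6-fold higher number from compound 2 to compound 3 (0.55 log units; beyond the scatter). Compound 3 is therefore estimated at 1500 nM, with a range from 300 nM to 7000 nM.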

Compound 3, half-maximal inhibitory concentration: 27000 nM
Estimate against measurement, compound 3: 18-fold (1.26 log units) below, outside the stated range (above it).
By their numbers in this assay, from the lowest: compound 2; then compounds 1 and 3 (each within the scatter of the next).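

In this assay, the result shows that the size of the earlier step on the sulfonyl sulfur does not carry over to an oxygen-linked chain: hexyloxy in place of diisobutylamino reverses it (a 64-fold higher number from compound 2 to compound 3 (1.81 log units; beyond the scatter)). Hexyloxy in place of pyrrolidin-1-yl makes no difference beyond the scatter (a 1.8-fold higher number from compound 1 to compound 3 (0.26 log units; within the scatter)), so among these compounds only diisobutylamino on this sulfur stands apart, with compound 1 and compound 3 level. Nothing available accounts for this difference.

Hexyloxy differs from diisobutylamino both in its linking atom and in having one unbranched chain rather than two branched ones, so the compounds shown do not separate these changes. An isobutoxy group or a dihexylamino group on the same sulfur would bear on that question.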